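The compounds below may be only part of what the source reports. "The series", "measured", "known", "first", "only" and "open" are said of these compounds alone.

Compound 1 `Cc1ccc(N2CCN(C(=S)SCc3ccc4nc(N)nc(N)c4c3)CC2)c(C)c1` is the stronger-looking of the two measured compounds, although by a margin that does not separate it from its neighbour. In a functional assay on HeLa cells (Homo sapiens) for antiproliferative activity, read by MTT assay, with a stated time of 72 h (a lower number here means a stronger inhibitor, a higher number a weaker inhibitor), compound 1 gives 3190 nM, the lowest number of the two, and in this assay compound 2 `Nc1nc(N)c2cc(CSC(=S)N3CCN(c4ccccc4Cl)CC3)ccc2n1` gives 4050 nM. For the measured compounds named here, the one step between them, a 1.3-fold higher number from compound 1 to compound 2 (0.10 log units; within the scatter), comes from a 2-chlorophenyl in place of a 2,4-dimethylphenyl on the amine nitrogen in the ring, so the two values cannot be told apart.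

Compound 3 `Nc1nc(N)c2cc(CSC(=S)N3CCN(c4ncccn4)CC3)ccc2n1` changes the same position: pyrimidin-2-yl in place of 2,4-dimethylphenyl on an amine nitrogen in a ring. Going by the values given here, the only step that bears on this, from compound 1 to compound 2, was within the scatter, so an exchange of the group on that ring nitrogen gave no clear movement in this assay. On that basis compound 3 is expected to give a number close to that of compound 1, with at most a small upward drift, a 1.4-fold higher number from compound 1 to compound 3 (0.15 log units; within the scatter). The estimate for compound 3 in this assay is 4500 nM, within a range of 2000 nM to 10000 nM.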

Compound 3, half-maximal inhibitory concentration: 4360 nM
Beside the measured number, compound 3's estimate is 1.0-fold (0.01 log units) above it; measured number inside the range.
By their numbers in this assay, from the lowest: compounds 1, 2 and 3 (each within the scatter of the next).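

For the compounds shown here, compound 3 puts a six-membered aromatic ring with 2 hetero atoms and 2 hydrogen-bond acceptors on the ring nitrogen, where the earlier compounds carried only aromatic rings of carbon. In this assay, this exchange gives a 1.4-fold higher number from compound 1 to compound 3 (0.14 log units; within the scatter), and against the 2-chlorophenyl group it gives a 1.1-fold higher number from compound 2 to compound 3 (0.03 log units; within the scatter), so all three groups on this nitrogen remain within the scatter of one another. No measurement is available here that would explain this result.

All three compounds carry a six-membered aromatic ring on this nitrogen, so the compounds shown leave open whether a methyl, an acetyl or a benzyl group there would give a step beyond the scatter. They also say nothing about changes elsewhere in the shared core.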